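Aryl sulfonate series: alkylphenyl returns in place of trichlorophenyl

The compounds below may be only part of what the source reports. "The series", "measured", "known", "first", "only" and "open" are said of these compounds alone.

compound 1 `CCCN1CCN(c2ccc(S(=O)(=O)Oc3ccccc3CC)cc2)C1=O` — 2300 nM
compound 2 `CCCN1CCN(c2ccc(S(=O)(=O)Oc3c(Cl)cc(Cl)cc3Cl)cc2)C1=O` — > 100000 nM

In a functional assay on MCF7 cells (Homo sapiens) for antiproliferative activity, read by sulforhodamine B assay, with a stated time of 48 h (a lower number here means a stronger inhibitor, a higher number a weaker inhibitor), compound 1 gives 2300 nM. Compound 2 reaches only a limit in this assay, > 100000 nM (the limit of > 100000 nM in this assay, at which 1 of the 2 values shown sits), so its place on the scale is known only as a bound. For the measured compounds named here, the single measured step, an at least 43-fold higher number from compound 1 to compound 2 (1.63 log units; beyond the scatter), is large. Compound 3 `CCCN1CCN(c2ccc(S(=O)(=O)Oc3ccc(C)cc3)cc2)C1=O` differs from compound 2 by 4-methylphenyl in place of 2,4,6-trichlorophenyl on an oxygen. A 4-methylphenyl is nearer in kind to the 2-ethylphenyl of compound 1 than to the 2,4,6-trichlorophenyl, so most of that step is expected to reverse: an at least 33-fold lower number from compound 2 to compound 3 (1.52 log units; beyond the scatter). Compound 3 is estimated at 3000 nM, within 800 nM to 15000 nM.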

Compound 3, half-maximal inhibitory concentration: 64000 nM
Compound 3: middle estimate off by 21-fold (1.33 log units), on the low side; the whole stated range lies below it.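

The change of aryl group on this oxygen does not simply follow the alkylphenyl kind, and 4-methylphenyl does not return to the level of 2-ethylphenyl: there is a 28-fold higher number from compound 1 to compound 3 (1.44 log units; beyond the scatter). Against the trichlorophenyl, the only reading is a floor, an at least 1.5-fold lower number from compound 2 to compound 3 (0.19 log units; that floor lies within the scatter), so no real gain over it can be claimed. Compound 2 holds a limit and not a number: the limit of > 100000 nM in this assay, at which 1 of the 3 values shown sits.

Open, on these data alone, is whether the standing of compound 1 follows the ethyl chain itself or its place on the ring. A 2-methylphenyl or a 4-ethylphenyl on this oxygen would separate the two.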